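Methoxy for Nitro: Estimating Compound 4 in Mice

The compounds below may be only part of what the source reports. "The series", "measured", "known", "first", "only" and "open" are said of these compounds alone.

Measured compounds in a functional assay on the whole organism (strain Kunming) with Mus musculus as the target, in the maximal electroshock model, with a stated time of 4 h; a higher number here means that more compound is needed for the effect, a lower number that less compound is needed:
- compound 1 `CCC(CO)N1C(=O)NC2(CC2c2ccc3cccc(OCc4ccccc4)c3n2)C1=O` gives 30 mg/kg
- compound 2 `O=C1NC2(CC2c2ccc3cccc(OCc4ccccc4)c3n2)C(=O)N1Cc1ccccc1` gives 300 mg/kg
- compound 3 `O=C1NC2(CC2c2ccc3cccc(OCc4ccccc4)c3n2)C(=O)N1c1ccc([N+](=O)[O-])cc1` gives 300 mg/kg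

Compound 3 stands level with compound 2, the two together at the highest number of the three; no change at the digits printed from compound 2 to compound 3 (within the scatter). Compound 1 sits apart: a 10-fold higher number from compound 1 to compound 2 (1.00 log units; beyond the scatter) and a 10-fold higher number from compound 1 to compound 3 (1.00 log units; beyond the scatter).

Compound 4 `COc1ccc(N2C(=O)NC3(CC3c3ccc4cccc(OCc5ccccc5)c4n3)C2=O)cc1` differs from compound 3 as follows: methoxy in place of nitro on an aromatic carbon. Within the data shown here, none of the measured steps touches this position; the only step that keeps a ring on the amide-type nitrogen, no change at the digits printed from compound 2 to compound 3 (within the scatter), lies within the scatter, so no movement beyond the scatter is expected here. Compound 4 is therefore estimated at 300 mg/kg (range 100 mg/kg to 600 mg/kg), meaning an expected step of no change at the digits printed from compound 3 to compound 4 (within the scatter).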

Compound 4, minimum effective dose: 100 mg/kg
Estimate against measurement, compound 4: 3.0-fold (0.48 log units) above, and the stated range covers the measured number.
By their numbers in this assay, from the lowest: compound 1; then compound 4; then compounds 2 and 3 (each within the scatter of the next).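

In this assay, the group on this aromatic carbon proves to matter: methoxy in place of nitro gives a 3.0-fold lower number from compound 3 to compound 4 (0.48 log units; beyond the scatter), so the aryl substituent can move the dose needed even though the ring on the amide-type nitrogen stays. The 4-methoxyphenyl group also compares favourably with benzyl, giving a 3.0-fold lower number from compound 2 to compound 4 (0.48 log units; beyond the scatter), but it does not match 1-(hydroxymethyl)propyl, giving a 3.3-fold higher number from compound 1 to compound 4 (0.52 log units; beyond the scatter). Nothing available explains the shift. As far as these compounds go, it remains open whether losing nitro or gaining methoxy drives the change, and how an amine or a carboxylic acid on this carbon would behave.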